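A few compounds are considered here, and "the series" means these few. Any claim that something is new, unique, unknown or untested is made for them only; others in the source may bear on it.

Compound 1 `NCc1csc(NC(=O)c2ccc(Cl)cc2)n1`: 1.2; compound 2 `NCc1csc(NC(=O)c2ccn[nH]2)n1`: 0; compound 3 `CC(C)(C)c1cc(C(=O)Nc2ccccn2)n(Cc2ccccc2)n1`: 4.5.

In a physicochemical assay for lipophilicity, read by HPLC, at pH 3.0 (on this read-out lower numbers stand for lower lipophilicity and higher numbers for higher lipophilicity), compound 3 gives the highest of the three numbers. Compound 1 lies beyond the scatter below it, and compound 2 lies further below still, also beyond the scatter. Compound 4 `CN(C)Cc1csc(NC(=O)c2cc(C(C)(C)C)nn2Cc2ccccc2)n1` has not yet been measured. It differs from compound 3 in a single place: 4-((dimethylamino)methyl)-1,3-thiazol-2-yl in place of pyridin-2-yl on an amide-type nitrogen. Going by the values given here, no measured pair shows this exact change, so its effect cannot be read off directly. What the measured numbers do show is that compound 3 stands far above the other two, and that compound 1 and compound 2, both built on a thiazole, sit low in this assay. A large downward step is expected, beyond the scatter, and the step from compound 3 to compound 4 is estimated at a number 2.50 log units lower from compound 3 to compound 4 (beyond the scatter). The expected value for compound 4 is 2, with a likely range from 1 to 3.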

Compound 4, distribution coefficient: 2.6
Compound 4: middle estimate off by 0.60 log units, on the low side; the range from low to high includes it.
By their numbers in this assay, from the lowest: compound 2; then compound 1; then compound 4; then compound 3.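

With the rest of compound 3 unchanged, placing 4-((dimethylamino)methyl)-1,3-thiazol-2-yl in place of pyridin-2-yl on an amide-type nitrogen gives a number 1.90 log units lower from compound 3 to compound 4 (beyond the scatter) in this assay. Going by these compounds alone, this is the first step that can be read at a single place, and it shows that the read-out responds strongly to the group at this position. The entering group has more heavy atoms than the one leaving, yet the number falls, so here a larger group did not bring a higher reading.

No measurement shown explains the fall. From the compounds shown here alone, the swap changes both the ring and its side chain, so it remains open which of them carries the step, and how the thiazole would read with a hydroxymethyl group or a carboxylic acid in place of the (dimethylamino)methyl group.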